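Swapping the amine end of the amide chain in compound 2

The source may hold more compounds than are shown below. What is called first, only, known or untested is meant among the compounds shown, and "the series" means these compounds.

Measured so far in an assay for activation of potassium voltage-gated channel subfamily KQT member 1 (Cavia porcellus); on this read-out higher numbers stand for weaker inhibition and lower numbers for stronger inhibition:
- compound 1, `CCCc1noc(-c2ccc(C(=O)NCC3CCCC3(C)C)cc2)n1`: 27 nM; 10 nM (2 entries)
- compound 2, `CCCCCCOc1ccc(C(=O)NCCN(CC)CC)cc1`: 3500 nM
- compound 3, `CCCCc1noc(-c2ccc(C(=O)NC[C@@H]3CCCC3(C)C)cc2)n1`: 9 nM

Compound 2 stands at the high end of the numbers seen: its nearest neighbour is compound 3, whose number lies far lower, a gap well beyond the usual scatter. Compound 1 is recorded twice, and its two entries the several entries of compound 1 in this assay, 27 nM; 10 nM (2 entries) sit close to each other and to compound 3. Going by the values given here, compound 2 differs from both of these in its core and in its amide side chain, so no single step connects it to them.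

Among the compounds with values here, the unmeasured compound 4, `CCCCCCOc1ccc(C(=O)NCCC(C)(C)C)cc1`, changes only one thing in compound 2: tert-butyl in place of diethylamino on a saturated chain carbon, two bonds along the chain from an amide-type nitrogen. The chain keeps its length; the nitrogen-bearing branch is traded for an all-carbon one.

Within the data shown here, no measured step covers this change. The potent compounds 1 and 3 both carry a saturated, nitrogen-free group on the amide, which is the only hint available. The step from compound 2 to compound 4 is therefore expected to go toward a lower number, and by a margin that may just clear the scatter, as a 3.5-fold lower number from compound 2 to compound 4 (0.54 log units; beyond the scatter). Compound 4 is estimated at 1000 nM in this assay, within a range from 200 nM to 5000 nM.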

Compound 4, half-maximal inhibitory concentration: 250 nM
For compound 4 the middle estimate is 4.0-fold (0.60 log units) above the measured one; low and high end bracket the measured number.
By their numbers in this assay, from the lowest: compound 3; then compound 4; then compound 2.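

In this assay, going by these compounds alone, tert-butyl in place of diethylamino on a saturated chain carbon, two bonds along the chain from an amide-type nitrogen, gives a 14-fold lower number from compound 2 to compound 4 (1.15 log units; beyond the scatter), and this large step is the first one here that can be read from a change in a single place. The earlier compounds shown here could not show this, since compound 2 differs from compound 1 and compound 3 in both its core and its amide side chain, whereas compound 4 keeps the core and chain length of compound 2 and changes only the group at the chain's end. The swap removes the nitrogen and the hydrogen-bond acceptor counted with it, but nothing measured here tells what lies behind the size of the step.

From the compounds shown here alone, it remains open whether the nitrogen itself matters most, which a dimethylamino, a piperidine or an isopropyl group at the same place could help to test. Going by these compounds, it is also open whether the step carries over to another core, as a 2-(diethylamino)ethyl group on the amide of compound 1 would show.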